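Moving the chloro around the pyridinyl ring: permeability

The source may hold more compounds than are shown below. What is called first, only, known or untested is meant among the compounds shown, and "the series" means these compounds.

Compound 1 `Cn1c(COc2cccc(C(=O)O)c2)nc2ccc(Oc3ccccn3)cc21`: 2.2 10^-6 cm/s
Compound 2 `Cn1c(COc2cccc(C(=O)O)c2)nc2ccc(Oc3cccc(Cl)n3)cc21`: 7.6 10^-6 cm/s
Compound 3 `Cn1c(COc2cccc(C(=O)O)c2)nc2ccc(Oc3ccc(Cl)cn3)cc21`: 16.2 10^-6 cm/s

In an ADME assay for permeability, using PAMPA, with a stated time of 4 h (on this read-out higher numbers stand for higher permeability and lower numbers for lower permeability), compound 3 gives the highest of the three numbers, with compound 2 nearest and compound 1 furthest. Compound 4 `Cn1c(COc2cccc(C(=O)O)c2)nc2ccc(Oc3cc(Cl)ccn3)cc21` differs from compound 3 by 4-chloropyridin-2-yl in place of 5-chloropyridin-2-yl on an oxygen on an aromatic ring. The step that bears on it most directly is a 2.1-fold higher number from compound 2 to compound 3 (0.33 log units; beyond the scatter), which also moved only the chloro on the pyridinyl ring; a 3.5-fold higher number from compound 1 to compound 2 (0.54 log units; beyond the scatter) and a 7.4-fold higher number from compound 1 to compound 3 (0.87 log units; beyond the scatter) show that either chloro raises the number over the unsubstituted pyridinyl of compound 1. Compound 4 is therefore expected to stay near the upper end, with an expected change of a 1.4-fold lower number from compound 3 to compound 4 (0.13 log units; within the scatter). The estimate for compound 4 is 12 10^-6 cm/s, ranging from 5 10^-6 cm/s to 30 10^-6 cm/s.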

Compound 4, apparent permeability: 10.3 10^-6 cm/s
Compound 4: the middle estimate sits 1.2-fold (0.07 log units) above what was measured; low and high end bracket the measured number.
By their numbers in this assay, from the lowest: compound 1; then compounds 2, 4 and 3 (each within the scatter of the next, the first and the last beyond it).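

In this assay the 4-chloropyridin-2-yl group keeps the gain over the unsubstituted pyridinyl, with a 4.7-fold higher number from compound 1 to compound 4 (0.67 log units; beyond the scatter). It cannot be told apart from the two other chloro placements, with a 1.6-fold lower number from compound 3 to compound 4 (0.20 log units; within the scatter) and a 1.4-fold higher number from compound 2 to compound 4 (0.13 log units; within the scatter), both within the scatter, although compound 2 and compound 3 lie beyond the scatter of each other. Nothing available here explains these numbers. On these data alone, whether a fluoro or a methoxy in place of the chloro would give a similar number stays open, as does the effect of an amide in place of the carboxylic acid.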